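Anilino in Place of Ethoxyethylamino on the Shared Core

The source may report more compounds than this note shows. Statements on the series, on what has been measured and on what is new or still open speak of the compounds shown alone.

Compound 3 `CCOCCNc1nc(C)c(-c2nc3ccccc3s2)c(N[C@@H]2C[C@H](CO)[C@@H](O)[C@H]2O)n1` stands highest of the two numbers in an ADME assay on cells (Homo sapiens) for cytotoxicity, read by polymerase chain reaction, with a stated time of 3 days (on this read-out lower numbers stand for higher toxicity in this test and higher numbers for lower toxicity in this test), where compound 3 gives 18000 nM. Compound 1 `Cc1nc(N)nc(N[C@@H]2C[C@H](CO)[C@@H](O)[C@H]2O)c1-c1nc2ccccc2s1` gives 4000 nM. Compound 2 `CNc1nc(C)c(-c2nc3ccccc3s2)c(N[C@@H]2C[C@H](CO)[C@@H](O)[C@H]2O)n1` reaches only a limit, > 25000 nM, as recorded in the limit of > 25000 nM in this assay, at which 1 of the 3 values shown sits. The change to compound 4 `Cc1nc(Nc2ccccc2)nc(N[C@@H]2C[C@H](CO)[C@@H](O)[C@H]2O)c1-c1nc2ccccc2s1` is phenyl in place of 2-ethoxyethyl on a nitrogen on an aromatic ring. Putting a group on this nitrogen raised the number twice: a 4.5-fold higher number from compound 1 to compound 3 (0.65 log units; beyond the scatter) and an at least 6.2-fold higher number from compound 1 to compound 2 (0.79 log units; beyond the scatter), while an at least 1.3-fold lower number from compound 2 to compound 3 (0.14 log units; that floor lies within the scatter). For the measured compounds named here, no measured step exchanges one substituent on this nitrogen for another of a different kind, so for compound 4 a step within the scatter is expected, no change at the digits printed from compound 3 to compound 4 (within the scatter). Compound 4 is therefore estimated at 18000 nM, with a range from 6000 nM to 50000 nM.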

Compound 4, half-maximal cytotoxic concentration: > 25000 nM
Compound 4 ended at the assay's limit (the forecaster's own chance of this, stated with the estimate: 40%); middle value at least 1.3-fold (0.14 log units) away from the limit.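

Compound 4 reaches only a limit, > 25000 nM, in this assay. With a ring on this nitrogen the read-out shows an at least 6.2-fold higher number from compound 1 to compound 4 (0.79 log units; beyond the scatter), so phenyl joins methyl and 2-ethoxyethyl in raising the number over the free amine of compound 1. The exchange of 2-ethoxyethyl for phenyl gives an at least 1.3-fold higher number from compound 3 to compound 4 (0.14 log units; that floor lies within the scatter), which does not separate the two groups.

From the compounds shown here alone, the step between compound 2 and compound 4 cannot be read, and the upper end stays unresolved: the limit of > 25000 nM in this assay, at which 2 of the 4 values shown sit. Whether a carboxylic acid or a longer chain on this nitrogen would also reach this limit remains open.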